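The source may hold more compounds than are shown below. What is called first, only, known or untested is meant among the compounds shown, and "the series" means these compounds.

Among the compounds with values here, compound 1 `O=C1/C(=C/c2coc3ccccc3c2=O)N=C(c2ccccc2)N1c1ccc(S(=O)(=O)Nc2nccs2)cc1` is the one compound here with a plain number: in a functional assay on A549 cells (Homo sapiens) for cytotoxicity, read by sulforhodamine B assay, with a stated time of 72 h (on this read-out higher numbers stand for weaker inhibition and lower numbers for stronger inhibition), compound 1 gives 88400 nM. Compound 2 `O=C1/C(=C/c2coc3ccccc3c2=O)N=C(c2ccc(Cl)cc2)N1c1ccc(S(=O)(=O)Nc2nccs2)cc1` reaches only the limit of the assay, > 100000 nM. Compound 3 `Cc1cc(NS(=O)(=O)c2ccc(N3C(=O)/C(=C/c4coc5ccccc5c4=O)N=C3c3ccc(Cl)cc3)cc2)no1` likewise reaches only a limit, > 100000 nM. The steps read an at least 1.1-fold higher number from compound 1 to compound 2 (0.05 log units; that floor lies within the scatter) and a step that the two limits leave unreadable from compound 2 to compound 3. Compound 4 `O=C1/C(=C/c2coc3ccccc3c2=O)N=C(c2ccccc2)N1c1ccc(S(=O)(=O)Nc2ncccn2)cc1` differs from compound 1 by pyrimidin-2-yl in place of 1,3-thiazol-2-yl on a sulfonamide nitrogen. Within the data shown here, the one measured step that also swaps the ring on that sulfonamide nitrogen is the one from compound 2 to compound 3, and it stays unreadable at the limit of > 100000 nM in this assay, at which 2 of the 3 values shown sit. With nothing readable to lean on, no change beyond the scatter is expected in this assay this assay. For compound 4 the estimate is 95000 nM, spanning 45000 nM to 200000 nM. The expected step is a 1.1-fold higher number from compound 1 to compound 4 (0.03 log units; within the scatter).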

Compound 4, half-maximal inhibitory concentration: 40500 nM
Beside the measured number, compound 4's estimate is 2.3-fold (0.37 log units) above it, and the stated range ends above it.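

In this assay, pyrimidin-2-yl in place of 1,3-thiazol-2-yl on the sulfonamide nitrogen gives a 2.2-fold lower number from compound 1 to compound 4 (0.34 log units; beyond the scatter). Within the data shown here, this is the first readable sign that the ring on this nitrogen can shift cytotoxicity, although the shift is modest. The earlier ring swap on this nitrogen, from compound 2 to compound 3, cannot be read because both compounds stop at a limit: the limit of > 100000 nM in this assay, at which 2 of the 4 values shown sit.

Still open, on these data alone, is whether a phenyl ring, or plain hydrogen, on this nitrogen would shift the number more. Also open, as far as these compounds go, is whether pyrimidin-2-yl has the same effect on the chloro-bearing core of compound 2.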